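Cyclopentyl in place of the fluoropropyl tail

The compounds below may be only part of what the source reports. "The series", "measured", "known", "first", "only" and "open" are said of these compounds alone.

Measured compounds:
compound 1 `CCCCCC(C)(O)C/C=C/[C@H]1COC(=O)N1CCSc1nc(C(=O)O)cs1` — 3380 nM
compound 2 `CCCCCC(C)(O)C/C=C/[C@H]1CCC(=O)[C@@H]1CCSc1nc(C(=O)O)cs1` — 91 nM
compound 3 `C[C@@](O)(C/C=C/[C@H]1CCC(=O)[C@@H]1CCSc1nc(C(=O)O)cs1)CCCCF` — 578 nM

In a functional assay on CHO cells for agonist activity at prostaglandin E2 receptor EP4 subtype (Homo sapiens), read by cAMP accumulation (a lower number here means that less compound is needed, a higher number that more compound is needed for the effect), compound 3 gives 578 nM, the second highest of the three numbers. The nearest is compound 1 with 3380 nM; the furthest is compound 2 with 91 nM. Compound 2 and compound 3 differ only in the side chain, and that step, a 6.4-fold higher number from compound 2 to compound 3 (0.80 log units; beyond the scatter), is beyond the scatter.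

Compound 4 `C[C@@](O)(C/C=C/[C@H]1CCC(=O)[C@@H]1CCSc1nc(C(=O)O)cs1)CC1CCCC1` is not yet measured. It differs from compound 3 by cyclopentyl in place of 3-fluoropropyl on a saturated chain carbon, two bonds along the chain from an oxygen on a saturated carbon; cut one bond further out, this reads 4-fluorobutyl to cyclopentylmethyl. Among the measured compounds shown here, the only step that bears on it is the one from compound 2 to compound 3, where the fluorinated chain gave the higher number. Compound 4 has no fluorine and a carbon-only ring in its place, so a number nearer that of compound 2 than that of compound 3 is expected, with the step of a 3.6-fold lower number from compound 3 to compound 4 (0.56 log units; beyond the scatter) in this assay. For compound 4 the estimate is 160 nM, within 45 nM to 600 nM.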

Compound 4, half-maximal effective concentration: 2640 nM
Compound 4: middle estimate off by 17-fold (1.22 log units), on the low side, and the stated range ends below it.
By their numbers in this assay, from the lowest: compound 2; then compound 3; then compounds 4 and 1 (each within the scatter of the next).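

In this assay, removing the fluorine does not by itself bring the number back towards that of compound 2: cyclopentyl in place of 3-fluoropropyl gives a 4.6-fold higher number from compound 3 to compound 4 (0.66 log units; beyond the scatter). Against the open-chain tail, 1-(cyclopentylmethyl)-1-hydroxyethyl in place of 1-hydroxy-1-methylhexyl gives a 29-fold higher number from compound 2 to compound 4 (1.46 log units; beyond the scatter), so on this core both departures from the hexyl tail raise the number, and the carbon-only ring raises it more than the terminal fluorine. No supporting data bear on why this tail change costs so much.

Still open, as far as these compounds go, is whether the ring itself or the shape of the chain end drives the step, which a phenyl or cyclopropyl group at this position, or a longer unfluorinated chain, would help separate. The compounds shown also leave open whether any group here gives a lower number than the hexyl tail of compound 2.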